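Working notes: fluoro for methyl, compound 1 to compound 4

The source may hold more compounds than are shown below. What is called first, only, known or untested is meant among the compounds shown, and "the series" means these compounds.

Measured so far in a functional assay on MGC-803 cells (Homo sapiens) for inhibition, read by MTT assay, with a stated time of 48 h; on this read-out lower numbers stand for stronger inhibition and higher numbers for weaker inhibition:
Compound 1 `C/C=C/C(=O)N(Cc1ccc(OC)c(C)c1)c1cc(OC)c(OC)c(OC)c1` gives 14500 nM.
Compound 2 `COc1ccc(CN(C(=O)CCCl)c2cc(OC)c(OC)c(OC)c2)cc1O` gives 140 nM.
Compound 3 `COc1ccc(CN(C(=O)CCCCCl)c2cc(OC)c(OC)c(OC)c2)cc1O` gives 540 nM.

Compound 1 stands at the highest of the three numbers; compound 3 is nearest and compound 2 furthest, both gaps beyond the scatter. Compound 4 `C/C=C/C(=O)N(Cc1ccc(OC)c(F)c1)c1cc(OC)c(OC)c(OC)c1` differs from compound 1 by fluoro in place of methyl on an aromatic carbon. Going by the values given here, the only measured step, a 3.9-fold higher number from compound 2 to compound 3 (0.59 log units; beyond the scatter), concerns the saturated chain beside the carbonyl carbon, not the six-membered aromatic ring, so it does not bear on this change; no measured pair sets fluoro against methyl. With nothing relevant to go on, no shift beyond the scatter is expected for compound 4 in this assay, and the estimated step is a 1.2-fold lower number from compound 1 to compound 4 (0.08 log units; within the scatter). Compound 4 is therefore expected to give about 12000 nM, in a range from 4000 nM to 40000 nM.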

Compound 4, half-maximal inhibitory concentration: 1650 nM
Compound 4: the middle estimate sits 7.3-fold (0.86 log units) above what was measured; the measured number lies below the stated range.
By their numbers in this assay, from the lowest: compound 2; then compound 3; then compound 4; then compound 1.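

In this assay, the aromatic carbon ortho to a methoxy group proves sensitive to a single-atom change: fluoro in place of methyl gives an 8.8-fold lower number from compound 1 to compound 4 (0.94 log units; beyond the scatter). Going by these compounds alone, the earlier step concerned only the saturated chain, so this is the first sign that the six-membered aromatic ring also affects the number. Nothing available here explains the shift.

On these data alone, how trifluoromethyl, a nitrile or an amine would read at this carbon remains open. So does whether fluoro would give a similar step with the saturated chloro chains of compound 2 and compound 3.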